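The source may hold more compounds than are shown below. What is called first, only, known or untested is meant among the compounds shown, and "the series" means these compounds.

In a functional assay on HepG2 cells (Homo sapiens) for antiproliferative activity, read by sulforhodamine B assay, with a stated time of 48 h (a lower number here means a stronger inhibitor, a higher number a weaker inhibitor), compound 1 (`COc1ccc(C=C(C(=O)/C=C/c2cccc(OC)c2OC)C(=O)/C=C/c2cccc(OC)c2OC)cc1OC`) gives 200 nM and compound 2 (`COc1cccc(/C=C/C(=O)C(=Cc2ccc(OC)c(OC)c2OC)C(=O)/C=C/c2cccc(OC)c2OC)c1OC`) gives 240 nM while compound 3 (`COc1cc(OC)c(/C=C/C(=O)C(=Cc2ccc(O)c(OC)c2)C(=O)/C=C/c2c(OC)cc(OC)cc2OC)c(OC)c1`) gives 670 nM as the highest number of the three. Against compound 3, compound 4 (`COc1cc(OC)c(/C=C/C(=O)C(=Cc2ccc(O)c(F)c2)C(=O)/C=C/c2c(OC)cc(OC)cc2OC)c(OC)c1`) shows fluoro in place of methoxy on an aromatic carbon as fluoro in place of methoxy on an aromatic carbon, ortho to a hydroxy group. Within the data shown here, the only measured step is a 1.2-fold higher number from compound 1 to compound 2 (0.08 log units; within the scatter) for methoxy in place of hydrogen on an aromatic carbon and lies within the scatter. Among the measured compounds shown here, no measured pair exchanges methoxy for fluoro, so this step bears only loosely on the change. No step beyond the scatter is therefore expected in this assay in either direction. The expected step is a 1.1-fold lower number from compound 3 to compound 4 (0.05 log units; within the scatter) and carries no firm direction. For compound 4 the estimated value is 600 nM with 250 nM to 1400 nM as the expected range.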

Compound 4, half-maximal inhibitory concentration: 810 nM
Estimate against measurement, compound 4: 1.4-fold (0.13 log units) below, and the stated range covers the measured number.
By their numbers in this assay, from the lowest: compounds 1 and 2 (each within the scatter of the next); then compounds 3 and 4 (each within the scatter of the next).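

In this assay, fluoro in place of methoxy, ortho to a hydroxy group, gives a 1.2-fold higher number from compound 3 to compound 4 (0.08 log units; within the scatter), so this position accepts the exchange without a readable change. The earlier step covered only methoxy in place of hydrogen; this one shows that the methoxy here can leave for a smaller group, at least on the core of compound 3. Nothing available bears on what lies behind this result.

As far as these compounds go, whether an amine or a chloro group would be accepted at this position stays open. So does whether the exchange reads the same with the hydroxy group replaced by methoxy.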